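The source may report more compounds than this note shows. Statements on the series, on what has been measured and on what is new or still open speak of the compounds shown alone.

Three compounds share one core and differ only in the group on a saturated chain carbon bound to an amine nitrogen in a ring. Compound 1 `COc1ccc2[nH]c3c(c2c1)CCNC31CCN(Cc2ccccc2)CC1` carries phenyl there, and in an assay on FRT cells for positive allosteric modulation of Cystic fibrosis transmembrane conductance regulator variant N1303K (Homo sapiens), in the presence of a further agent that is not named here (a lower number here means that less compound is needed, a higher number that more compound is needed for the effect), compound 1 gives 12600 nM. Compound 2 `COc1ccc2[nH]c3c(c2c1)CCNC31CCN(Cc2cc(F)ccc2F)CC1` carries 2,5-difluorophenyl, and in this assay compound 2 gives 11100 nM. Compound 3 `COc1ccc2[nH]c3c(c2c1)CCNC31CCN(Cc2c(F)c(F)c(F)c(F)c2F)CC1` carries the fully fluorinated ring, and in this assay compound 3 gives 2100 nM. Compound 2 thus stands second highest of the three numbers: its value and that of compound 1 lie within the scatter of each other, while compound 3 sits clearly lower.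

Compound 4 `COc1ccc2[nH]c3c(c2c1)CCNC31CCN(Cc2cccnc2)CC1` has not been measured. (pyridin-3-yl in place of 2,5-difluorophenyl on a saturated chain carbon bound to an amine nitrogen in a ring). Among the measured compounds shown here, the only measured step at this position is a 1.1-fold lower number from compound 1 to compound 2 (0.06 log units; within the scatter), which changed the ring without effect beyond the scatter. For the measured compounds named here, no measured step exchanges a carbon-only ring for one holding a nitrogen, so nothing points to a shift in either direction. For compound 4 the expected step is therefore a 1.2-fold higher number from compound 2 to compound 4 (0.07 log units; within the scatter), within the scatter. Compound 4 is estimated in this assay at 13000 nM, between 4500 nM and 40000 nM.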

Compound 4, half-maximal effective concentration: 17000 nM
For compound 4 the middle estimate is 1.3-fold (0.12 log units) below the measured one, and the stated range covers the measured number.
By their numbers in this assay, from the lowest: compound 3; then compounds 2, 1 and 4 (each within the scatter of the next).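

In this assay the exchange of a carbon-only ring for one holding a nitrogen reads as a 1.5-fold higher number from compound 2 to compound 4 (0.19 log units; within the scatter) and, measured against the plain phenyl, as a 1.3-fold higher number from compound 1 to compound 4 (0.13 log units; within the scatter) and neither step leaves the scatter. On a saturated chain carbon bound to an amine nitrogen in a ring, pyridin-3-yl therefore cannot be told apart from phenyl or 2,5-difluorophenyl, so the added hydrogen-bond acceptor and the ring nitrogen bring no readable change here, and compound 3 at 2100 nM still holds the lowest number of the four. No measurement is at hand that would explain this result.

The compounds shown leave open whether other ring nitrogen placements, as in pyridin-2-yl or pyridin-4-yl, would behave like pyridin-3-yl. They also leave open whether a tetrafluorophenyl or a pentafluorophenyl ring on a longer chain would keep the lower number seen for compound 3.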